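A few compounds are considered here, and "the series" means these few. Any claim that something is new, unique, unknown or untested is made for them only; others in the source may bear on it.

Measured so far in an ADME assay on HepG2 cells (Homo sapiens) for cytotoxicity, read by luminescence, with a stated time of 72 h; on this read-out lower numbers stand for an effect already at smaller amounts and higher numbers for an effect only at larger amounts of compound:
- Compound 1 `CCOC(=O)c1c(-c2cccc(OC)c2)[nH]c2cc(OC)c(Cl)cc2c1=O`: > 21500 nM
- Compound 2 `CCOC(=O)c1c(-c2cccc(-c3nc(C)c(C)s3)c2)[nH]c2cc(OC)c(F)cc2c1=O`: > 21500 nM
- Compound 3 `COc1cc2[nH]c(-c3cccc(Oc4ccccc4)c3)c(C(=O)NCCN3CCCC3)c(=O)c2cc1F`: > 21500 nM

All three entries are limits of the assay and not numbers, and the series stands at the limit of > 21500 nM in this assay, at which 3 of the 3 values shown sit. Compound 3 gives > 21500 nM, which is a limit. For the measured compounds named here, it therefore holds no rank among the three compounds, and no pair of them differs in only one place.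

Compound 4 `COc1cc2[nH]c(-c3cccc(Oc4ccccc4)c3)c(C(=O)OCCO)c(=O)c2cc1F` has not yet been measured. It departs from compound 3 at a single site: 2-hydroxyethoxy in place of (2-(pyrrolidin-1-yl)ethyl)amino on a carbonyl carbon. The (2-(pyrrolidin-1-yl)ethyl)carbamoyl of compound 3 thus becomes the (2-hydroxyethoxy)carbonyl of compound 4.

Going by the values given here, with no measured step to serve as a guide, the expectation is no change beyond the scatter, in either direction. The expected size is an estimated step that the limit leaves unreadable from compound 3 to compound 4. This expectation rests first on compound 3, whose > 21500 nM is a limit. An ester like compound 4, compound 2 gives > 21500 nM, again a limit. A reading that is again only a limit is thought the likeliest outcome. Should a number be obtained, the estimate for compound 4 is 30000 nM, with an expected range from 12000 nM to 60000 nM.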

Compound 4, half-maximal effective concentration: > 21500 nM
Compound 4: no number, only a limit; the forecaster's own chance of this, stated with the estimate: 80%; the middle value does not contradict the limit.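

In this assay compound 4 gives > 21500 nM, which is a limit. Compound 3 also stands at a limit, so no step can be read between compound 3 and compound 4. The compounds shown leave open at what concentration any of them would show an effect on these cells, and the series gives only one reading: the limit of > 21500 nM in this assay, at which 4 of the 4 values shown sit.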